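This account rests on a few compounds, and the source may have more. Where it says the series, first, only, none or still open, it means among the compounds named here.

Compound 1 `COc1ccc(C#N)cc1CSc1nc2cc(NC(=O)C3CC3)ccc2n1C(C)C`: in an assay on isolated protein for inhibition of Gonadotropin-releasing hormone receptor (Rattus norvegicus) (on this read-out lower numbers stand for stronger inhibition and higher numbers for weaker inhibition), compound 1 gives > 10000 nM, which is a limit of the assay, not a number.
Compound 2 `COCCn1c(SCc2cc([N+](=O)[O-])ccc2OC)nc2cc(NC(=O)NC(C)(C)C)ccc21`: in this assay compound 2 gives 280 nM.

Going by the values given here, compound 2 therefore stands as the only real number among the two; for compound 1 only the limit of > 10000 nM in this assay, at which 1 of the 2 values shown sits, is known. Compound 3 `COc1ccc([N+](=O)[O-])cc1CSc1nc2cc(NC(=O)NC(C)(C)C)ccc2n1-c1ccccc1` differs from compound 2 by phenyl in place of 2-methoxyethyl on an aromatic nitrogen. Among the compounds with values here, no measured pair isolates such a change, so the expectation rests on compound 2 alone; a modest step toward weaker inhibition is expected, a 1.6-fold higher number from compound 2 to compound 3 (0.21 log units; within the scatter). Compound 3 is thus expected to give 450 nM, within 100 nM to 2500 nM.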

Compound 3, half-maximal inhibitory concentration: > 2600 nM
Compound 3 ended at the assay's limit; the forecaster's own chance of this, stated with the estimate: 10%; middle value at least 5.7-fold (0.76 log units) away from the limit.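

In this assay, going by these compounds alone, this is the first single change to show that the group on the aromatic nitrogen matters: phenyl in place of 2-methoxyethyl gives an at least 9.2-fold higher number from compound 2 to compound 3 (0.96 log units; beyond the scatter). Compound 3 is known only through a limit, so the full size of the loss stays unknown: the limit of > 2600 nM in this assay, at which 1 of the 3 values shown sits.

From the compounds shown here alone, what remains open is whether the loss follows the arrival of the aromatic ring or the departure of the chain's oxygen. A butyl chain, with no ring and no oxygen, would help separate these two changes.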